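The source may hold more compounds than are shown below. What is called first, only, known or untested is meant among the compounds shown, and "the series" means these compounds.

Measured compounds:
compound 1, `CCCCCCCOc1ccc(NC(=O)Oc2ccccc2F)cc1` — 28 nM in an assay on H4 cells for inhibition of Fatty-acid amide hydrolase 1 (Homo sapiens); on this read-out higher numbers stand for weaker inhibition and lower numbers for stronger inhibition
compound 2, `CCCCCCOc1ccc(NC(=O)ON=C(C)C)cc1` — 18 nM in this assay

Compound 2 has the lowest number of the two, but the gap to compound 1 lies within the scatter, so neither can be called the stronger inhibitor. Compound 3, `CCCCCCOc1ccc(NC(=O)Oc2ccccc2F)cc1`, is not yet measured; it differs from compound 2 in one place: a group of 7 heavy atoms (6 carbon, 1 fluorine; one six-membered aromatic ring of carbon only) in place of a group of 4 heavy atoms (3 carbon, 1 nitrogen; no ring), on an oxygen next to a carbonyl group. Compound 3 shares its 2-fluorophenyl carbamate with compound 1, whose value is 28 nM, so compound 3 is expected to land near that, at 30 nM (range 10 nM to 90 nM). The expected step of a 1.7-fold higher number from compound 2 to compound 3 (0.22 log units; within the scatter) stays within the scatter, no clear direction.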

Compound 3, half-maximal inhibitory concentration: 710 nM
Compound 3: the middle estimate sits 24-fold (1.37 log units) below what was measured; measured number above the stated range.
By their numbers in this assay, from the lowest: compounds 2 and 1 (each within the scatter of the next); then compound 3.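

In this assay, 2-fluorophenyl on the oxygen next to a carbonyl group, in place of the group of 4 heavy atoms, gives a large change: a 39-fold higher number from compound 2 to compound 3 (1.60 log units; beyond the scatter). Hydrogen in place of methyl on a saturated chain carbon, six bonds along the chain from an oxygen on an aromatic ring, also matters greatly: a 25-fold higher number from compound 1 to compound 3 (1.40 log units; beyond the scatter). So 2-fluorophenyl alone does not set the number; the chain matters too.

Nothing available explains either step. Still open, going by these compounds, is whether plain phenyl on that oxygen, or a longer chain, would keep the number low.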